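The source may hold more compounds than are shown below. What is called first, only, known or untested is meant among the compounds shown, and "the series" means these compounds.

In a physicochemical assay for solubility (on this read-out lower numbers stand for lower solubility and higher numbers for higher solubility), compound 1 `O=C(c1cccc(Cl)c1)N1CCC(NS(=O)(=O)c2cc(S(=O)(=O)c3ccccc3)ccc2C(F)(F)F)CC1` gives 6300 nM and compound 2 `O=C(c1ccc(C(F)(F)F)cc1)N1CCC(NS(=O)(=O)c2cc(S(=O)(=O)c3ccccc3)ccc2C(F)(F)F)CC1` gives 6300 nM, while compound 3 `O=C(c1ccc(Cl)nc1)N1CCC(NS(=O)(=O)c2cc(S(=O)(=O)c3ccccc3)ccc2C(F)(F)F)CC1` gives 25000 nM, the highest of the three. Compound 4 `CC(C)(C)OC(=O)N1CCC[C@@H]1C(=O)N1CCC(NS(=O)(=O)c2cc(S(=O)(=O)c3ccccc3)ccc2C(F)(F)F)CC1` remains unmeasured and differs from compound 3 as follows: 1-(tert-butoxycarbonyl)pyrrolidin-2-yl in place of 6-chloropyridin-3-yl on a carbonyl carbon. The group on the carbonyl carbon has already produced a 4.0-fold higher number from compound 1 to compound 3 (0.60 log units; beyond the scatter) and a 4.0-fold higher number from compound 2 to compound 3 (0.60 log units; beyond the scatter), both modest, whereas no change at the digits printed from compound 1 to compound 2 (within the scatter) stays within the scatter. None of these steps brings in a non-aromatic group, so they give only a rough guide to size in this assay. The expected result is a modest move back from the top of the series, namely a 2.5-fold lower number from compound 3 to compound 4 (0.40 log units; beyond the scatter). Compound 4 is estimated at 10000 nM, with an expected range of 3000 nM to 35000 nM.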

Compound 4, solubility: 25000 nM
Beside the measured number, compound 4's estimate is 2.5-fold (0.40 log units) below it, within the range that was stated.
By their numbers in this assay, from the lowest: compounds 1 and 2 (each within the scatter of the next); then compounds 3 and 4 (each within the scatter of the next).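

In this assay, among the compounds shown here, the only non-aromatic group in the set, 1-(tert-butoxycarbonyl)pyrrolidin-2-yl, shows no change at the digits printed from compound 3 to compound 4 (within the scatter) against 6-chloropyridin-3-yl, so at this position on the carbonyl carbon an aromatic ring is not required for the top of the series. The same group gives a 4.0-fold higher number from compound 2 to compound 4 (0.60 log units; beyond the scatter) and a 4.0-fold higher number from compound 1 to compound 4 (0.60 log units; beyond the scatter) against the two phenyl groups. No measurement shown bears on the reason for this result. Still open, going by these compounds, is whether the free pyrrolidin-2-yl amine, without its tert-butoxycarbonyl, would sit with compound 3 and compound 4 or with compound 1 and compound 2. The same question stands for a carboxylic acid or a plain alkyl chain on that carbonyl carbon.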